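This account rests on a few compounds, and the source may have more. Where it says the series, first, only, none or still open, it means among the compounds named here.

Measured in a functional assay on SW-620 cells (Homo sapiens) for inhibition, read by sulforhodamine B assay, with a stated time of 48 h; a higher number here means a weaker inhibitor of growth, a lower number a stronger inhibitor of growth:
Compound 1 `COc1cc(-c2cc(/C=C/C(=O)c3ccc(N)cc3)[nH]n2)cc(OC)c1OC`: 6370 nM
Compound 2 `COc1ccc(C(=O)/C=C/c2cc(-c3cc(OC)c(OC)c(OC)c3)n[nH]2)cc1OC`: 2990 nM

Compound 2 holds the lower of the two numbers. Going by the values given here, the only measured step, a 2.1-fold lower number from compound 1 to compound 2 (0.33 log units; beyond the scatter), came from 3,4-dimethoxyphenyl in place of 4-aminophenyl on a carbonyl carbon. Compound 3 `COc1cc(-c2cc(/C=C/C(=O)c3ccc(F)c(F)c3)[nH]n2)cc(OC)c1OC` differs from compound 2 at that same carbonyl carbon: 3,4-difluorophenyl in place of 3,4-dimethoxyphenyl on a carbonyl carbon. Among the compounds with values here, no measured step exchanges a methoxy-bearing ring for a fluorine-bearing one, so that single step gives only weak guidance. Compound 3 is expected to give 4000 nM, within 1500 nM to 12000 nM. The expected step is a 1.3-fold higher number from compound 2 to compound 3 (0.13 log units; within the scatter), possibly within the scatter.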

Compound 3, concentration for total growth inhibition: > 100000 nM
Compound 3: only a limit was reported (the forecaster's own chance of this, stated with the estimate: 10%); middle value at least 25-fold (1.39 log units) from the limit.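

In this assay the group on the carbonyl carbon can matter far more than the earlier pair showed: 3,4-difluorophenyl gives an at least 33-fold higher number from compound 2 to compound 3 (1.52 log units; beyond the scatter) against 3,4-dimethoxyphenyl and an at least 15-fold higher number from compound 1 to compound 3 (1.19 log units; beyond the scatter) against 4-aminophenyl. The substitution pattern alone therefore does not keep growth inhibition, since compound 2 and compound 3 share it and differ in what the ring carries. Compound 3 has no true number, only a limit of the assay: the limit of > 100000 nM in this assay, at which 1 of the 3 values shown sits.

On these data alone, its real distance from compound 2 stays unknown. As far as these compounds go, whether phenyl, 4-fluorophenyl or 3,4-dichlorophenyl on the carbonyl carbon would behave like compound 2 or like compound 3 remains open.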